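The source may hold more compounds than are shown below. What is called first, only, known or untested is meant among the compounds shown, and "the series" means these compounds.

Measured so far in an assay for inhibition of acyl-CoA:cholesterol acyltransferase (Oryctolagus cuniculus), using microsomes; a higher number here means a weaker inhibitor, a lower number a stronger inhibitor:
- compound 1, `CCCCCCCCCCCCCCCC(=O)Nc1c(C)cc(C)c2c1OC(C)(C)C2`: 26 nM
- compound 2, `CCCCCCCCCCCCC(C)(C)C(=O)Nc1c(C)cc(C)c2c1OC(C)(C)C2`: 33 nM

Compound 1 gives 26 nM in this assay, and compound 2 gives 33 nM. For the measured compounds named here, compound 2 thus holds the higher of the two numbers, but its only neighbour, compound 1, lies within the usual scatter of it, so the two cannot be told apart on these data, and neither can be called the stronger inhibitor.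

Compound 3, `Cc1cc(C)c(NC(=O)C(C)(C)CCCCCOc2ccc(Cl)cc2)c2c1CC(C)(C)O2`, has not yet been measured in this assay. It differs from compound 2 in one place: 4-chlorophenoxy in place of heptyl on a saturated chain carbon, six bonds along the chain from a carbonyl carbon. The amide and the shared core are kept unchanged.

Going by the values given here, no measured pair shows an exchange of this kind, so its size cannot be read from a step between known compounds. The step expected here, a 1.5-fold higher number from compound 2 to compound 3 (0.18 log units; within the scatter), is a small one toward a somewhat higher number, not clearly beyond the scatter. Compound 3 is therefore estimated at 50 nM, with a range from 15 nM to 170 nM.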

Compound 3, half-maximal inhibitory concentration: 150 nM
The estimate for compound 3 lay 3.0-fold (0.48 log units) below the measured number; the measured number falls inside the stated range.
By their numbers in this assay, from the lowest: compounds 1 and 2 (each within the scatter of the next); then compound 3.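

In this assay, for the compounds shown here, putting 4-chlorophenoxy in place of heptyl on a saturated chain carbon, six bonds along the chain from a carbonyl carbon, gives a 4.5-fold higher number from compound 2 to compound 3 (0.66 log units; beyond the scatter), the first step here that can be read between two compounds differing in one place. It shows that this end of the chain is not indifferent to what it carries: the exchange brings in an aromatic ring and an ether oxygen, and the number rises beyond the scatter, though only modestly. Nothing available bears on why the number rises, and the step alone does not tell which part of the new group goes with the change.

The compounds shown leave open how much of the step belongs to the chlorine, the ether oxygen or the aromatic ring, a question that plain phenoxy or 4-chlorophenyl at the same place could address. They also leave open whether a longer chain carrying the 4-chlorophenoxy, or a different ring substituent such as fluorine or methoxy, would bring the number back towards that of compound 2.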